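The source may report more compounds than this note shows. Statements on the series, on what has been measured and on what is new or still open speak of the compounds shown alone.

Measured so far:
- compound 1 `O=C(NCCCCc1ccccc1)c1cccc(C2SCC(=O)N2c2ccccn2)c1` gives 19.7 nM
- compound 2 `COc1cccc(OC)c1N1C(=O)CSC1c1cccc(C(=O)NCCCCc2ccccc2)c1` gives > 1000 nM

Both readings come from a functional assay on HOS-TE85 cells (Homo sapiens) for inhibition, read by CCK-8 assay, with a stated time of 72 h; a lower number here means a stronger inhibitor, a higher number a weaker inhibitor. Compound 2 stands at the limit of > 1000 nM in this assay, at which 1 of the 2 values shown sits, so its entry is a limit and not a number.

Compound 3 `O=C(NCCCCc1ccccc1)c1cccc(C2SCC(=O)N2c2ccccc2F)c1` carries 2-fluorophenyl in place of 2,6-dimethoxyphenyl on an amide-type nitrogen in a ring.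

For the measured compounds named here, one measured step bears on this place: an at least 50-fold higher number from compound 1 to compound 2 (1.70 log units; beyond the scatter), a large change beyond the scatter, on bringing in 2,6-dimethoxyphenyl. Compound 3 loses that group and is therefore expected to move back toward compound 1, which gives 19.7 nM. With a single step as the basis, a full return is not assumed.

In this assay a large step to a lower number is expected: an at least 8.3-fold lower number from compound 2 to compound 3 (0.92 log units; beyond the scatter). For compound 3 the estimate is 120 nM, with an expected range from 25 nM to 600 nM.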

Compound 3, half-maximal inhibitory concentration: 34.1 nM
Compound 3: the middle estimate sits 3.5-fold (0.55 log units) above what was measured; measured number inside the range.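

In this assay, the group on the amide-type nitrogen in the ring need not be pyridin-2-yl, as replacing it with 2-fluorophenyl gives a 1.7-fold higher number from compound 1 to compound 3 (0.24 log units; within the scatter); across compound 1 and compound 3, a nitrogen in this aromatic ring is therefore not required for a reading in this range. A carbon-only aromatic ring at this place does not by itself go with the loss seen with 2,6-dimethoxyphenyl. Bringing in 2-fluorophenyl, which also has such a ring, gives an at least 29-fold lower number from compound 2 to compound 3 (1.46 log units; beyond the scatter). The size of that step is only a lower bound, and the entry for compound 2 is a limit and not a number: the limit of > 1000 nM in this assay, at which 1 of the 3 values shown sits.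

On these data alone, whether one methoxy group, as in 2-methoxyphenyl, is enough to produce the loss or whether both in 2,6-dimethoxyphenyl are needed remains open. Also open, as far as these compounds go, is how a dimethylamino group or a carboxylic acid on this aromatic ring would read.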